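From compound 2 to compound 4: one aryl swap

The source may report more compounds than this note shows. Statements on the series, on what has been measured and on what is new or still open speak of the compounds shown alone.

Of the compounds shown here, three have been tested in an ADME assay on KB cells (Homo sapiens) for cytotoxicity, read by MTT assay, with a stated time of 72 h; a higher number here means a weaker inhibitor, a lower number a stronger inhibitor: compound 1 (`COc1ccc(C2=C(c3cc(OC)c(OC)c(OC)c3)C(=O)C(O)C2)cc1NC(=O)c1ccccc1`), compound 2 (`COC(=O)c1cc(C2=C(c3cc(OC)c(OC)c(OC)c3)C(=O)CC2O[SiH2]C(C)(C)C)ccc1OC`) and compound 3 (`COc1ccc(C2=C(c3cc(OC)c(OC)c(OC)c3)C(=O)CC2O)cc1O`). None of them gives an exact number. Compound 1 reads > 100 ug/mL and this is a limit of the assay. Compound 2 reads > 100 ug/mL and this is also a limit. Compound 3 reads < 1 ug/mL and this too is a limit, on the opposite side. Compound 2 therefore sits on the weak side, in the limit of > 100 ug/mL in this assay, at which 2 of the 3 values shown sit, of the set. The other side holds the limit of < 1 ug/mL in this assay, at which 1 of the 3 values shown sits, of the set.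

Compound 4 (`COc1cc(C2=C(c3ccccc3)C(O[SiH2]C(C)(C)C)CC2=O)cc(OC)c1OC`) has not yet been measured. It differs from compound 2 in one place (phenyl in place of 4-methoxy-3-(methoxycarbonyl)phenyl on a double-bonded ring carbon): phenyl in place of 4-methoxy-3-(methoxycarbonyl)phenyl on a double-bonded ring carbon. Among the compounds with values here, no measured pair isolates this swap, so the forecast rests on the closest neighbour. Compound 2 at > 100 ug/mL is that neighbour, and its limit anchors the expectation. The expected step of a number no higher from compound 2 to compound 4 (the limit leaves the size open) is estimated to stay within the usual scatter, with no clear direction. For compound 4 the estimate is 100 ug/mL with an expected range from 30 ug/mL to 300 ug/mL and the assay may well report only a limit again.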

Compound 4, half-maximal inhibitory concentration: > 100 ug/mL
Compound 4: no number, only a limit; the forecaster's own chance of this, stated with the estimate: 70%; the middle value lies on the limit itself.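

In this assay compound 2 gives > 100 ug/mL, a limit and not a number. Compound 4 gives > 100 ug/mL, again a limit, so the step between these two compounds cannot be read. Still open, as far as these compounds go, is how far each compound lies from that limit, and so whether phenyl in place of 4-methoxy-3-(methoxycarbonyl)phenyl changes the read-out at all.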